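Fluoro in place of chloro: compound 2 to compound 3

The source may hold more compounds than are shown below. What is called first, only, known or untested is meant among the compounds shown, and "the series" means these compounds.

In a functional assay on Huh-7 cells (Homo sapiens) for inhibition, read by CCK-8 assay, with a stated time of 72 h (a lower number here means a stronger inhibitor, a higher number a weaker inhibitor), compound 1 `Cc1ccccc1NS(=O)(=O)c1cccc(CCCCCCNC(=O)/C=C/c2cccnc2)c1` gives 0.525 nM and compound 2 `O=C(/C=C/c1cccnc1)NCCCCCCc1cccc(S(=O)(=O)Nc2ccc(Cl)cc2)c1` gives 24.1 nM, the higher of the two numbers and so the weaker inhibitor. Compound 3 `O=C(/C=C/c1cccnc1)NCCCCCCc1cccc(S(=O)(=O)Nc2ccc(F)cc2)c1` carries fluoro in place of chloro on an aromatic carbon, para to a large group: fluoro in place of chloro on an aromatic carbon. Going by the values given here, the only measured step touching this part of the molecule is a 46-fold higher number from compound 1 to compound 2 (1.66 log units; beyond the scatter), with 4-chlorophenyl in place of 2-methylphenyl on a sulfonamide nitrogen. That step is large and beyond the scatter, so this assay can respond strongly to changes here. However, it replaces a different group, and no measured pair isolates fluoro against chloro. A much smaller change is therefore expected, with no firm direction. The estimated step is a 1.2-fold lower number from compound 2 to compound 3 (0.08 log units; within the scatter), expected to stay within the scatter. For compound 3 the estimate is 20 nM, with an expected range of 6 nM to 60 nM.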

Compound 3, half-maximal inhibitory concentration: 4.28 nM
For compound 3 the middle estimate is 4.7-fold (0.67 log units) above the measured one; measured number outside the range, below it.
By their numbers in this assay, from the lowest: compound 1; then compound 3; then compound 2.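

In this assay, the atom on the aromatic carbon para to a large group matters even in a swap of one halogen for another: fluoro in place of chloro gives a 5.6-fold lower number from compound 2 to compound 3 (0.75 log units; beyond the scatter). The 4-fluorophenyl group therefore recovers part of the loss seen with 4-chlorophenyl, but it does not match the 2-methylphenyl group on the sulfonamide nitrogen, with an 8.2-fold higher number from compound 1 to compound 3 (0.91 log units; beyond the scatter). Nothing available accounts for the gap between fluoro and chloro at this position.

Still open, going by these compounds, is how a methoxy or a nitrile in place of the fluoro would stand in this assay, so two halogens do not yet define a trend. Also open, on these data alone, is whether a longer chain in the shared core would keep the same order among compound 1, compound 3 and compound 2.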